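Adding a Methyl to the Phenyl of Compound 3

The compounds below may be only part of what the source reports. "The series", "measured", "known", "first", "only" and "open" are said of these compounds alone.

Compound 1 `COc1ccc(Nc2cc(C(C)C)oc(=O)c2)cc1` is measured in a functional assay on A549 cells (Homo sapiens) for cytotoxicity, read by MTT assay, with a stated time of 72 h; a lower number here means that less compound is needed, a higher number that more compound is needed for the effect. For compound 1 the value > 30 uM is a limit of the assay rather than a number (the limit of > 30 uM in this assay, at which 1 of the 3 values shown sits). Compound 2 `COc1ccc(Nc2cc(/C=C/c3ccccc3)oc(=O)c2)cc1` gives 0.11 uM, and the step of an at least 270-fold lower number from compound 1 to compound 2 (2.43 log units; beyond the scatter) is large. Compound 3 `O=c1cc(Nc2ccccc2)cc(-c2ccccc2)o1` gives 0.12 uM, the highest of the two numbers, yet its nearest neighbour compound 2 sits within the scatter of it. Compound 4 `Cc1ccc(Nc2cc(-c3ccccc3)oc(=O)c2)cc1` differs from compound 3 by methyl in place of hydrogen on an aromatic carbon. Going by the values given here, no measured step touches this ring; the only measured step, between compound 1 and compound 2, changed the group on the other side of the shared core, so it offers no guide here. A step within the scatter is therefore expected. Compound 4 is expected to give 0.12 uM, with a range from 0.04 uM to 0.4 uM. This corresponds to an expected no change at the digits printed from compound 3 to compound 4 (within the scatter).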

Compound 4, concentration for half-maximal effect: 0.067 uM
For compound 4 the middle estimate is 1.8-fold (0.25 log units) above the measured one, within the range that was stated.
By their numbers in this assay, from the lowest: compounds 4, 2 and 3 (each within the scatter of the next). At a limit, above all of these: compound 1.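

The step shown at this position, phenyl to 4-methylphenyl, is a 1.8-fold lower number from compound 3 to compound 4 (0.25 log units; within the scatter) in this assay. A methyl can therefore sit on this ring without moving the number beyond the scatter, so this change, unlike the large step at the other side of the shared core, leaves the number where it was. Nothing shown gives a reason for this small step.

Only methyl is compared directly with hydrogen here. As far as these compounds go, whether a carboxylic acid, an amine or a longer chain at this position would also stay within the scatter remains open.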